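Acetyl to dimethylamino on the outer phenyl ring

A few compounds are considered here, and "the series" means these few. Any claim that something is new, unique, unknown or untested is made for them only; others in the source may bear on it.

Measured compounds:
compound 1 `COc1cc(C)cc(-c2c(-c3ccnc(-c4ccc(C(C)=O)cc4)c3)cnn2CC#N)c1` — 60%
compound 2 `COc1cc(C)cc(-c2nn(CC#N)cc2-c2ccnc(-c3ccc(N(C)C)cc3)c2)c1` — 31%
compound 3 `Cc1cc(O)cc(-c2nn(CC#N)cc2-c2ccnc(-c3ccc(N(C)C)cc3)c2)c1` — 64%

In a functional assay on OVCAR-5 cells (Homo sapiens) for cytotoxicity, read by sulforhodamine B assay, with a stated time of 48 h, tested at 1 uM (on this read-out lower numbers stand for a stronger effect and higher numbers for a weaker effect at the one concentration tested), compound 1 gives 60%, which is the second highest of the three numbers. Compound 3 lies close to it, within the usual scatter, while compound 2 sits well below, beyond the scatter. For the measured compounds named here, the only single-place step among the measured compounds is a number 33 percentage points higher from compound 2 to compound 3 (beyond the scatter), which concerns a change on the phenol oxygen and not the group studied here.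

Compound 4 `COc1cc(C)cc(-c2c(-c3ccnc(-c4ccc(N(C)C)cc4)c3)cnn2CC#N)c1` differs from compound 1 in one place: dimethylamino in place of acetyl on an aromatic carbon. Going by the values given here, no measured step covers this exact change, so the expectation rests on a weaker hint: compound 2, which also carries a dimethylamino group, gives 31%, whereas compound 1 with its acetyl group gives 60%; the two, however, also differ elsewhere, so this is not a clean comparison.

On that basis a lower number, meaning a stronger effect, is expected for compound 4, with the step estimated as a number 20 percentage points lower from compound 1 to compound 4 (beyond the scatter), though it could also remain within the scatter. The estimate for compound 4 is 40%, with a range from 22% to 62%.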

Compound 4, a percentage reported as activity, at one concentration (the size of the read-out at that concentration, not a potency): 81%
Compound 4: middle estimate off by 41 percentage points, on the low side; measured number above the stated range.
By their numbers in this assay, from the lowest: compound 2; then compounds 1 and 3 (each within the scatter of the next); then compound 4.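

In this assay the swap on the outer phenyl ring gives a number 21 percentage points higher from compound 1 to compound 4 (beyond the scatter) and so, at this place para to a large group, the dimethylamino group goes with a weaker effect than the acetyl group. This is the only direct reading of the swap among the compounds shown, and the two groups match in heavy-atom count and in hydrogen-bond donor and acceptor counts, so those counts do not separate them even though the number moves beyond the usual scatter. Nothing available here explains the direction of this step.

As far as these compounds go, whether a carboxylic acid or a simple primary amine at the same place would give a stronger or weaker effect than the acetyl group remains open, as does whether the swap would run the same way with the hydroxyl group of compound 3 in place of the methoxy group. From the compounds shown here alone, with readings at only one concentration, it also remains open whether compound 4 would still show a weaker effect than compound 1 at other concentrations.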